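The source may report more compounds than this note shows. Statements on the series, on what has been measured and on what is new or still open speak of the compounds shown alone.

Measured so far in a functional assay on NCI-H3122 cells (Homo sapiens) for antiproliferative activity, read by MTT assay, with a stated time of 48 h; a lower number here means a stronger inhibitor, a higher number a weaker inhibitor:
Compound 2, `Cc1ccc(CNC(=O)c2cccc(C(C)Oc3ccnc(Nc4cnn(C5CCN(C)CC5)c4)c3)c2)cc1`, gives 8900 nM.
Compound 3, `CC(Oc1ccnc(Nc2cnn(C3CCN(C)CC3)c2)c1)c1cccc(C(=O)NCc2ccc(Cl)c(C(F)(F)F)c2)c1`, gives 8000 nM.
Compound 1, `CC(Oc1cccnc1Nc1cnn(C)c1)c1cccc(C(=O)NCc2ccc(Cl)c(C(F)(F)F)c2)c1`, gives 50700 nM.

Compound 2 stands second highest of the three numbers in this assay. Its nearest neighbour is compound 3, reached by a 1.1-fold lower number from compound 2 to compound 3 (0.05 log units; within the scatter), a change at the amide end that stays within the scatter. Going by the values given here, compound 1 gives a clearly higher number, but it differs from compound 2 in more than one place, so no single step connects them.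

Compound 4, `Cc1ccc(CNC(=O)c2cccc(C(C)Oc3ccnc(Nc4cn(C)nc4C)c3)c2)cc1`, differs from compound 2 by 1,3-dimethyl-1H-pyrazol-4-yl in place of 1-(1-methylpiperidin-4-yl)-1H-pyrazol-4-yl on a nitrogen on an aromatic ring. Among the compounds with values here, no measured step touches this part of the shared core; the one step known, from compound 2 to compound 3, lies at the other end. Compound 1 also carries a methylpyrazole yet differs elsewhere too, so its value cannot be read as a guide to this change alone. The expectation is therefore uncertain, leaning to a somewhat higher number: for compound 4 the estimate in this assay is 15000 nM, with a range from 4000 nM to 60000 nM, meaning an expected step of a 1.7-fold higher number from compound 2 to compound 4 (0.23 log units; within the scatter).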

Compound 4, half-maximal inhibitory concentration: 13400 nM
Beside the measured number, compound 4's estimate is 1.1-fold (0.05 log units) above it; low and high end bracket the measured number.
By their numbers in this assay, from the lowest: compounds 3, 2 and 4 (each within the scatter of the next); then compound 1.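

In this assay, 1,3-dimethyl-1H-pyrazol-4-yl in place of 1-(1-methylpiperidin-4-yl)-1H-pyrazol-4-yl on a nitrogen on an aromatic ring gives a 1.5-fold higher number from compound 2 to compound 4 (0.18 log units; within the scatter). The six-membered non-aromatic ring can therefore leave this position with no step beyond the scatter, as seen for this one pair. No available evidence bears on this result. Open, as far as these compounds go, is whether a carboxylic acid or an open-chain dimethylaminoethyl group on the pyrazole would give a step beyond the scatter. Also open, from the compounds shown here alone, is how 4-chloro-3-(trifluoromethyl)phenyl at the amide end behaves alongside 1,3-dimethyl-1H-pyrazol-4-yl.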